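Amide-side variation: compounds 1 to 3

The source may report more compounds than this note shows. Statements on the series, on what has been measured and on what is new or still open speak of the compounds shown alone.

Measured so far:
compound 1, `CC(C)c1c(C(=O)NCc2ccccn2)nn(-c2ccc(F)cc2)c1OC[C@@H](O)C[C@@H](O)CC(=O)O`: 25 nM
compound 2, `COc1cc(CN(C)C(=O)c2nn(-c3ccc(F)cc3)c(OC[C@@H](O)C[C@@H](O)CC(=O)O)c2C(C)C)cc(OC)c1`: 43 nM

In an assay on microsomes from liver for inhibition of 3-hydroxy-3-methylglutaryl-coenzyme A reductase (Rattus norvegicus) (a higher number here means a weaker inhibitor, a lower number a stronger inhibitor), compound 1 gives 25 nM and compound 2 gives 43 nM. Within the data shown here, only these two numbers exist so far, and the gap between them lies within the scatter, so neither compound can be set apart from the other. Among the measured compounds shown here, no step between measured compounds that differ in one place is available.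

Compound 3, `CC(C)c1c(C(=O)N(C)Cc2ccc(F)cc2)nn(-c2ccc(F)cc2)c1OC[C@@H](O)C[C@@H](O)CC(=O)O`, differs from compound 2 in one place: 4-fluorophenyl in place of 3,5-dimethoxyphenyl on a saturated chain carbon bound to an amide-type nitrogen. The methyl group on the amide-type nitrogen stays as in compound 2. Compounds 1 and 2 already carry different groups on the carbon bound to the amide-type nitrogen and still sit within the scatter of each other, which hints that this position tolerates change, though two points cannot establish that. The step is therefore expected to be small, in no particular direction, and not beyond the scatter; the estimated step is a 1.3-fold lower number from compound 2 to compound 3 (0.13 log units; within the scatter). Compound 3 is expected to give about 32 nM in this assay, with a range from 12 nM to 85 nM.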

Compound 3, half-maximal inhibitory concentration: 18 nM
For compound 3 the middle estimate is 1.8-fold (0.25 log units) above the measured one; low and high end bracket the measured number.
By their numbers in this assay, from the lowest: compounds 3, 1 and 2 (each within the scatter of the next, the first and the last beyond it).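

In this assay, 4-fluorophenyl in place of 3,5-dimethoxyphenyl on a saturated chain carbon bound to an amide-type nitrogen gives a 2.4-fold lower number from compound 2 to compound 3 (0.38 log units; beyond the scatter). Among these compounds, this is the first step beyond the scatter, so the group at this position is not wholly without influence on the read-out, though the step is modest and rests on a single pair. Exchanging the whole group on the carbonyl carbon, with (4-fluorobenzyl)(methyl)amino in place of ((pyridin-2-yl)methyl)amino, gives a 1.4-fold lower number from compound 1 to compound 3 (0.14 log units; within the scatter), which leaves these two compounds inseparable, and no measurement at hand accounts for either step.

The compounds shown leave open whether the step from 3,5-dimethoxyphenyl to 4-fluorophenyl follows from losing the two methoxy groups or from gaining the fluorine, a question that plain phenyl at this position would address. They also leave open what the methyl group on the amide-type nitrogen contributes on its own, which (4-fluorobenzyl)amino on the carbonyl carbon would separate from the change of ring.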